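From ethyl to 4-methylphenyl on the sulfonyl sulfur

The source may hold more compounds than are shown below. What is called first, only, known or untested is meant among the compounds shown, and "the series" means these compounds.

Compound 1 `CCS(=O)(=O)N1CCC2(CC1)OOC1(CCCCCC1)OO2` is the starting point, tested in a functional assay on Huh-7 cells (Homo sapiens) for cytotoxicity, read by MTT assay, with a stated time of 72 h; a higher number here means that more compound is tolerated, a lower number that less compound is tolerated. Compound 1 gives > 100 ug/mL, which is a limit of the assay and not a number. Compound 2 `CCCCS(=O)(=O)N1CCC2(CC1)OOC1(CCCC1)OO2` gives > 100 ug/mL, also a limit. Compound 3 `CCCCS(=O)(=O)N1CCC2(CC1)OOC1(CCCCC1)OO2` gives > 100 ug/mL, again a limit. Compound 1 therefore stands with the other two, and the whole picture so far is the limit of > 100 ug/mL in this assay, at which 3 of the 3 values shown sit. Among the measured compounds shown here, no measured pair yet shows how large a single structural change can be in this assay.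

Compound 4 `Cc1ccc(S(=O)(=O)N2CCC3(CC2)OOC2(CCCCCC2)OO3)cc1` keeps the core of compound 1 and changes one group, with 4-methylphenyl in place of ethyl on a sulfonyl sulfur. This brings in an aromatic ring that none of the three measured compounds carries, so the forecast is uncertain.

The expectation rests on compound 1, whose reading is > 100 ug/mL, a limit. No step beyond the usual scatter is expected, and any real shift would most likely be towards less compound being tolerated. The estimated change is a number no higher from compound 1 to compound 4 (the limit leaves the size open). The assay may well report only a limit again. For compound 4 the expected value is 100 ug/mL, with an estimated range from 40 ug/mL to 200 ug/mL.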

Compound 4, half-maximal cytotoxic concentration: > 100 ug/mL
Compound 4: a limit, no number; the forecaster's own chance of this, stated with the estimate: 65%; the middle value sits exactly at the limit.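

Compound 4 gives > 100 ug/mL in this assay, which is a limit of the assay and not a number. Among the compounds shown here, compound 1 also stands at a limit, so no step from compound 1 to compound 4 can be read. Going by these compounds, how much compound these four structures tolerate beyond that limit, and whether they differ at all, stays open.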